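This account rests on a few compounds, and the source may have more. Where it says the series, first, only, none or still open, it means among the compounds named here.

Compound 2 `COc1ccc(C(=O)/C=C/c2ccc(OCc3cn(Cc4ccccc4)nn3)cc2)cc1` stands highest of the three measured compounds in a functional assay on HepG2 cells (Homo sapiens) for inhibition, read by MTT assay, with a stated time of 48 h, tested at 10 uM (on this read-out lower numbers stand for less inhibition of growth and higher numbers for more inhibition of growth at the one concentration tested), where compound 2 gives 51%. Compound 1 `O=C(/C=C/c1ccc(OCc2cn(Cc3ccccc3)nn2)cc1)c1ccc(Br)cc1` gives 22% and compound 3 `COc1ccc(C(=O)/C=C/c2ccc(OCc3cn(Cc4cccc(F)c4)nn3)cc2)cc1` gives 22%; both connecting steps, a number 29 percentage points higher from compound 1 to compound 2 (beyond the scatter) and a number 29 percentage points lower from compound 2 to compound 3 (beyond the scatter), lie beyond the scatter. Compound 4 `O=C(/C=C/c1ccc(OCc2cn(Cc3ccccc3)nn2)cc1)c1ccc([N+](=O)[O-])cc1` differs from compound 2 by nitro in place of methoxy on an aromatic carbon. Of the measured steps only a number 29 percentage points higher from compound 1 to compound 2 (beyond the scatter) concerns this same position, and it shows that exchanging the group there moves this assay by a modest amount; the step of a number 29 percentage points lower from compound 2 to compound 3 (beyond the scatter) concerns a different part of the structure. For the measured compounds named here, no nitro analogue has been measured, so a modest decrease is expected, a number 19 percentage points lower from compound 2 to compound 4 (beyond the scatter). Compound 4 is accordingly estimated at 32%, within 10% to 55%.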

Compound 4, percent growth inhibition at one concentration: "not active" (no number reported)
The entry for compound 4 holds no number, so the estimate cannot be set against anything.
By their numbers in this assay, from the lowest: compounds 1 and 3 (each within the scatter of the next); then compound 2.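

Compound 4 carries no number in this assay so no step from compound 2 to compound 4 can be read, and no measurement at hand explains that entry. The compounds shown leave open where compound 4 would stand numerically beside compounds 1, 2 and 3.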